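Swapping a Pyridine Substituent: What Happens to Half-Life?

This account rests on a few compounds, and the source may have more. Where it says the series, first, only, none or still open, it means among the compounds named here.

Compound 1 `COc1nc2ccc(Br)cc2cc1[C@@H](c1cc(C)c(C)s1)[C@@](O)(CCN(C)C)c1cccc(F)c1`: 1 h
Compound 2 `COc1nc2ccc(Br)cc2cc1[C@@H](c1ccc(N(C)C)nc1)[C@@](O)(CCN(C)C)c1cccc(F)c1`: 0.3 h

Among the measured compounds shown here, in an ADME assay on microsomes from liver (Homo sapiens) for metabolic stability (a higher number here means that the compound lasts longer, a lower number that the compound disappears faster), compound 2 holds the lower of the two numbers, and compound 1 is the only measured neighbour. Compound 3 `COc1cc([C@H](c2cc3cc(Br)ccc3nc2OC)[C@@](O)(CCN(C)C)c2cccc(F)c2)cnc1OC` keeps the shared core and changes one group: 5,6-dimethoxypyridin-3-yl in place of 6-(dimethylamino)pyridin-3-yl on a saturated chain carbon bound to an aromatic carbon and a saturated chain carbon. Here, 5,6-dimethoxypyridin-3-yl takes the place of 6-(dimethylamino)pyridin-3-yl. For the measured compounds named here, only one measured step bears on this place: a 3.3-fold lower number from compound 1 to compound 2 (0.52 log units; beyond the scatter). This modest step shows that the group here can shift the number, but it involves a different exchange. Going by the values given here, no measured compound carries the incoming group, so neither size nor direction is firmly supported. A small rise from the low starting point is the tentative expectation. The expected change is a 1.7-fold higher number from compound 2 to compound 3 (0.22 log units; within the scatter), which may not clear the usual scatter. Compound 3 is estimated at 0.5 h, with an expected range from 0.2 h to 1.2 h.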

Compound 3, half-life: 0.317 h
Compound 3: the middle estimate sits 1.6-fold (0.20 log units) above what was measured, and the stated range covers the measured number.
By their numbers in this assay, from the lowest: compounds 2 and 3 (each within the scatter of the next); then compound 1.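

In this assay, the step to 5,6-dimethoxypyridin-3-yl in place of 6-(dimethylamino)pyridin-3-yl is a 1.1-fold higher number from compound 2 to compound 3 (0.02 log units; within the scatter), so these two groups cannot be told apart at this position, even though one carries oxygen atoms and the other an extra nitrogen. Compared with 4,5-dimethylthiophen-2-yl, the new group gives a 3.2-fold lower number from compound 1 to compound 3 (0.50 log units; beyond the scatter), so both substituted pyridines now lie beyond the scatter from the thiophene compound, and neither goes against this among the three compounds. Nothing measured here gives a reason for this pattern.

The compounds shown leave open whether the lower number goes with the pyridine itself or with the groups it carries. An unsubstituted phenyl or an unsubstituted pyridin-3-yl at this place would help to separate the two.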